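The source may hold more compounds than are shown below. What is called first, only, known or untested is meant among the compounds shown, and "the series" means these compounds.

Measured compounds:
compound 1, `CNC(=O)c1cc(C(=O)N[C@H]2[C@@H]3COC[C@@H]32)cc2c1OC[C@H]2c1cccnc1`: 1.4
compound 2, `CNC(=O)c1cc(C(=O)NC)c2c(c1)[C@](C)(c1ccccc1)CO2`: 3.4
compound 3, `CNC(=O)c1cc(C(=O)N[C@H]2[C@@H]3COC[C@@H]32)cc2c1OC[C@@]2(CO)c1ccccc1`: 2.4

In a physicochemical assay for lipophilicity, at pH 7.4 (on this read-out higher numbers stand for higher lipophilicity and lower numbers for lower lipophilicity), compound 2 stands highest of the three numbers; compound 3 lies nearer, beyond the scatter below it, and compound 1 lies furthest, also beyond the scatter. Compound 4, `CNC(=O)c1cc(C(=O)N[C@H]2C[C@@H]2C)cc2c1OC[C@@]2(C)c1ccccc1`, has not been measured. It differs from compound 2 by a single change: 2-methylcyclopropyl in place of methyl on an amide-type nitrogen. Among the measured compounds shown here, no step between two measured compounds of this set covers the same change, so the expectation rests on the added carbon count alone. Compound 4 is expected to give a clearly higher number in this assay than compound 2, a step of a number 0.80 log units higher from compound 2 to compound 4 (beyond the scatter) that should exceed the scatter. The estimate for compound 4 is 4.2, within a range from 3.7 to 4.7.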

Compound 4, distribution coefficient: 4.7
Compound 4: middle estimate off by 0.50 log units, on the low side, and the stated range covers the measured number.
By their numbers in this assay, from the lowest: compound 1; then compound 3; then compound 2; then compound 4.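

In this assay, putting 2-methylcyclopropyl in place of methyl on the amide-type nitrogen gives a number 1.30 log units higher from compound 2 to compound 4 (beyond the scatter), the only single-place step among these compounds. It shows that this position responds strongly to a change that adds only carbon and a three-membered ring, with no hydrogen-bond donor or acceptor entering or leaving. Nothing shown explains the size of this step. The compounds leave open whether an unsubstituted cyclopropyl, a longer chain or an amine at this nitrogen would move the number as far, and whether either stereocentre of the 2-methylcyclopropyl group matters.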